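Thiophene to thiazole on the aminomethyl arm

The source may hold more compounds than are shown below. What is called first, only, known or untested is meant among the compounds shown, and "the series" means these compounds.

Measured so far in an assay for inhibition of Caspase-8 (Homo sapiens); on this read-out higher numbers stand for weaker inhibition and lower numbers for stronger inhibition:
- Compound 1, `CC[C@@H](C(=O)N[C@@H](CC(=O)O)C(=O)CSCc1ccccc1)n1cccc(NC(=O)[C@H](CC(=O)O)NC(C)=O)c1=O`, gives 220 nM.
- Compound 2, `CCCCCCN(C)CNCC(=O)[C@H](CC(=O)O)NC(=O)C(CC)n1ccnc(NCc2nonc2C)c1=O`, gives only a limit of this assay, > 10000 nM.
- Compound 3, `CCC(C(=O)N[C@@H](CC(=O)O)C(=O)CSCc1ccccc1)n1ccnc(NCc2cccs2)c1=O`, gives 2090 nM.

Compound 3 stands on the highest of the two numbers shown in this assay; its nearest neighbour is compound 1, whose lower number lies beyond the usual scatter. The third value is the limit of > 10000 nM in this assay, at which 1 of the 3 values shown sits. Going by the values given here, no pair among the measured compounds differs in a single place, so no measured step is available as a guide.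

Compound 4, `CCC(C(=O)N[C@@H](CC(=O)O)C(=O)CSCc1ccccc1)n1ccnc(NCc2cncs2)c1=O`, departs from compound 3 by 1,3-thiazol-5-yl in place of thiophen-2-yl on a saturated chain carbon bound to a nitrogen on an aromatic ring. A five-membered aromatic ring remains at that position, with one further ring nitrogen. Among the compounds with values here, with no measured step to rest on, the expectation is a small step, either none beyond the scatter or a mild drift towards a higher number, so the step from compound 3 to compound 4 is estimated at a 1.3-fold higher number from compound 3 to compound 4 (0.13 log units; within the scatter). Compound 4 is therefore expected at about 2800 nM in this assay, within a range of 900 nM to 8000 nM.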

Compound 4, half-maximal inhibitory concentration: 6590 nM
Beside the measured number, compound 4's estimate is 2.4-fold (0.37 log units) below it; the range from low to high includes it.
By their numbers in this assay, from the lowest: compound 1; then compound 3; then compound 4. At a limit, above all of these: compound 2.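

In this assay the only single-place step among the compounds shown reads a 3.2-fold higher number from compound 3 to compound 4 (0.50 log units; beyond the scatter). The ring on a saturated chain carbon bound to a nitrogen on an aromatic ring is therefore not a silent position: replacing thiophen-2-yl with 1,3-thiazol-5-yl keeps five heavy atoms and adds one ring nitrogen, yet moves the read-out towards weaker inhibition. Nothing at hand accounts for the size or direction of this step.

A single pair cannot show whether the step follows from the added ring nitrogen as such or from where it stands in the ring, and 1,3-thiazol-2-yl at the same place would bear on that. On these data alone, whether a six-membered ring such as phenyl or pyridin-3-yl would be tolerated there also remains open.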